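Shortening the Alkyl Chain on a Lysosomal Glucosidase Inhibitor

This account rests on a few compounds, and the source may have more. Where it says the series, first, only, none or still open, it means among the compounds named here.

Compound 1, `CCCCCC[C@]1(CO)NC[C@H](O)[C@@H](O)[C@@H]1O`: 6.1 nM
Compound 2, `CCN1C[C@H](O)[C@@H](O)[C@H](O)[C@H]1CO`: 210 nM

In an assay on isolated protein for inhibition of lysosomal alpha-glucosidase (Homo sapiens), read by fluorescence, with stated times of 45 min and 30 min (a higher number here means a weaker inhibitor, a lower number a stronger inhibitor), compound 1 gives 6.1 nM, the lowest of the two numbers, and compound 2 gives 210 nM, a gap well beyond the scatter. Compound 3, `C[C@]1(CO)NC[C@H](O)[C@@H](O)[C@@H]1O`, is not yet measured; it differs from compound 1 by hydrogen in place of pentyl on a saturated chain carbon bound to a saturated ring carbon. Within the data shown here, no two measured compounds differ in a single place, so no measured step guides this change. A weaker inhibitor is expected, the step of a 25-fold higher number from compound 1 to compound 3 (1.39 log units; beyond the scatter) being clearly beyond the scatter. Compound 3 is therefore estimated at 150 nM, with a range of 30 nM to 800 nM.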

Compound 3, inhibition constant: 37000 nM
Compound 3: middle estimate off by 250-fold (2.39 log units), on the low side; the whole stated range lies below it.
By their numbers in this assay, from the lowest: compound 1; then compound 2; then compound 3.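

In this assay, among these compounds, hydrogen in place of pentyl on a saturated chain carbon bound to a saturated ring carbon brings a 6100-fold higher number from compound 1 to compound 3 (3.78 log units; beyond the scatter) and so gives the first step in this set that changes one place only. It shows that inhibition at the level of compound 1 is lost by a wide margin when pentyl leaves this position. Nothing available accounts for the size of this loss.

The compounds shown leave open how the number changes along the way from hydrogen to pentyl, as with a propyl chain at this place. They also leave open whether a longer chain such as octyl, or a benzyl group, would keep or lower the number of compound 1.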